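Swapping a Methylphenyl Amide for a Phenethyl Amide

The compounds below may be only part of what the source reports. "The series", "measured", "known", "first", "only" and "open" are said of these compounds alone.

Compound 1 `O=C(NC(=S)N1CCc2c(OCCCCCOc3ccc(Cl)cc3)cccc21)c1ccc(Cl)cc1`: 21700 nM
Compound 2 `O=C(NC(=S)N1CCc2c(OCCCCCOc3ccc(Cl)cc3)cccc21)c1ccc(Br)cc1`: 29100 nM
Compound 3 `Cc1ccc(C(=O)NC(=S)N2CCc3c(OCCCCCOc4ccc(Cl)cc4)cccc32)cc1`: > 50000 nM

These three share one core and differ only in the group on the carbonyl carbon. In an ADME assay on Huh-7 cells (Homo sapiens) for cytotoxicity (a lower number here means that less compound is tolerated, a higher number that more compound is tolerated), compound 3 gives > 50000 nM, which is a limit of the assay and not a number; it sits at the limit of > 50000 nM in this assay, at which 1 of the 3 values shown sits. Compound 4 `O=C(CCc1ccccc1)NC(=S)N1CCc2c(OCCCCCOc3ccc(Cl)cc3)cccc21` carries phenethyl in place of 4-methylphenyl on a carbonyl carbon. The measured steps only exchange one group on the aromatic ring: a 1.3-fold higher number from compound 1 to compound 2 (0.13 log units; within the scatter) and an at least 2.3-fold higher number from compound 1 to compound 3 (0.36 log units; beyond the scatter), together with an at least 1.7-fold higher number from compound 2 to compound 3 (0.23 log units; that floor lies within the scatter). None exchanges the aromatic ring itself for a chain, so the guidance is loose. In this assay compound 4 is expected to remain near the upper end, with an expected step of an at least 1.2-fold lower number from compound 3 to compound 4 (0.09 log units; that floor lies within the scatter) of no clear direction. Compound 4 is therefore estimated at 40000 nM, between 15000 nM and 90000 nM.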

Compound 4, half-maximal cytotoxic concentration: > 50000 nM
Compound 4 was reported as a limit (the forecaster's own chance of this, stated with the estimate: 45%); middle value at least 1.2-fold (0.09 log units) from the limit.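

In this assay compound 4 gives > 50000 nM, which is a limit of the assay and not a number. So the aromatic ring need not sit directly on the carbonyl carbon for a compound to reach this limit, since a phenethyl group does so as well, with an at least 2.3-fold higher number from compound 1 to compound 4 (0.36 log units; beyond the scatter) and an at least 1.7-fold higher number from compound 2 to compound 4 (0.23 log units; that floor lies within the scatter). Compound 4 now shares this ceiling with compound 3: the limit of > 50000 nM in this assay, at which 2 of the 4 values shown sit.

The step between compound 3 and compound 4 cannot be read, as both values are limits. On these data alone, whether a benzyl group, a longer chain or an amine on the carbonyl carbon would stay at this limit remains open.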